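One ring swap on compound 2

The source may hold more compounds than are shown below. What is called first, only, known or untested is meant among the compounds shown, and "the series" means these compounds.

Values so far in a physicochemical assay for solubility, in simulated intestinal fluid, with a stated time of 5 h, at pH 6.5 (a higher number here means a more soluble compound, a lower number a less soluble compound), are these:
- compound 1 `Cc1cc(Nc2ccc(S(F)(F)(F)(F)F)cc2)n2nc(C(F)(F)F)nc2n1` gives 5.1 ug/mL
- compound 2 `Cc1c(Cc2ccc(C(F)(F)F)nc2)c[nH]c1C(=O)NC(C)c1cnn(C)c1` gives 60 ug/mL

Compound 2 stands as the higher of the two, and its gap to compound 1 lies beyond the scatter of the measurement. Among the compounds with values here, these two compounds differ in more than one place, and no measured step speaks directly to the next change. Compound 3 `Cc1cc(C(C)NC(=O)c2[nH]cc(Cc3ccc(C(F)(F)F)nc3)c2C)no1` differs from compound 2 in one place only (5-methyl-1,2-oxazol-3-yl in place of 1-methyl-1H-pyrazol-4-yl on a saturated chain carbon bound to an amide-type nitrogen and a saturated chain carbon) on a saturated chain carbon bound to an amide-type nitrogen and a saturated chain carbon. The expectation therefore starts from compound 2 at 60 ug/mL and remains uncertain. A small fall is expected (a 1.7-fold lower number from compound 2 to compound 3 (0.23 log units; within the scatter)) and it may stay within the scatter. Compound 3 is estimated at 35 ug/mL with 12 ug/mL to 90 ug/mL as its expected range.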

Compound 3, solubility: 9.9 ug/mL
Beside the measured number, compound 3's estimate is 3.5-fold (0.55 log units) above it; measured number outside the range, below it.
By their numbers in this assay, from the lowest: compounds 1 and 3 (each within the scatter of the next); then compound 2.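

In this assay the swap of 1-methyl-1H-pyrazol-4-yl for 5-methyl-1,2-oxazol-3-yl gives a 6.1-fold lower number from compound 2 to compound 3 (0.78 log units; beyond the scatter) and thus shows that the read-out responds to this position, on a saturated chain carbon bound to an amide-type nitrogen and a saturated chain carbon. The two groups match in heavy atoms, hydrogen-bond donors and acceptors, ring size, hetero atoms in the ring and net charge, so these counts alone do not track the step. Nothing measured here bears on the origin of this step.

On these data alone, it remains open how an unsubstituted 1,2-oxazole, an amine or a carboxylic acid at this position would read in this assay. Also open, as far as these compounds go, is whether the same swap would give a similar step on a different core.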